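Amino in Place of Iodo: What Compound 4 May Show

The source may hold more compounds than are shown below. What is called first, only, known or untested is meant among the compounds shown, and "the series" means these compounds.

Measured in a functional assay on the whole organism with Mus musculus as the target, in the maximal electroshock model, with a stated time of 30 min; on this read-out lower numbers stand for an effect already at smaller amounts and higher numbers for an effect only at larger amounts of compound:
- compound 1, `N#Cc1ccccc1NC(=O)Nc1ccncc1`: > 300 mg/kg
- compound 2, `Nc1ccccc1NC(=O)Nc1ccncc1`: > 300 mg/kg
- compound 3, `O=C(Nc1ccncc1)Nc1ccc(I)cc1`: > 300 mg/kg

Compound 3 stands at the top of the numbers shown in this assay. Its reading is a limit of the assay, not a number. Compound 1 and compound 2 sit at the same place, so that the limit of > 300 mg/kg in this assay, at which 3 of the 3 values shown sit, covers every measured compound here, and no value below it has been seen.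

Compound 4, `Nc1ccc(NC(=O)Nc2ccncc2)cc1`, has not yet been measured. It differs from compound 3 in one place: amino in place of iodo on an aromatic carbon

Among the measured compounds shown here, only one measured step exists, a step that the two limits leave unreadable from compound 1 to compound 2, and it concerns a different pair of groups at a different position. Its size cannot be read, as both of its ends are limits. For the measured compounds named here, no measured step therefore bears directly on the change from compound 3 to compound 4, and nothing in the data points to a move away from the limit in either direction.

Compound 4 is accordingly expected to give about 300 mg/kg in this assay, with a range from 100 mg/kg to 900 mg/kg, most likely reported again as a limit. The expected step from compound 3 is a number no higher from compound 3 to compound 4 (the limit leaves the size open), that is, no change beyond the scatter.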

Compound 4, minimum effective dose: > 300 mg/kg
Compound 4 ended at the assay's limit; the forecaster's own chance of this, stated with the estimate: 80%; the middle value sits exactly at the limit.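

No step from compound 3 to compound 4 can be read in this assay, since each compound gives a limit of the assay rather than a number: the limit of > 300 mg/kg in this assay, at which 4 of the 4 values shown sit.

The compounds shown leave open whether amino in place of iodo changes the minimum effective dose at all, and at what dose any of these compounds would act.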